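A single swap at the low end of the doses

This account rests on a few compounds, and the source may have more. Where it says the series, first, only, none or still open, it means among the compounds named here.

In a functional assay on the whole organism with Canis familiaris (Canis lupus familiaris) as the target (on this read-out higher numbers stand for an effect only at larger amounts of compound and lower numbers for an effect already at smaller amounts), compound 3 (`COc1ccc(-c2nc3c[nH]cnc-3n2)c(OC)c1`) gives 0.3 mg/kg as its half-maximal dose, level with compound 2 (`COc1ccc(-c2nc3cc[nH]cc-3n2)c(OC)c1`) at 0.3 mg/kg at the digits shown, and the two together hold the lowest number of the three. Compound 1 (`CSc1ccc(-c2nc3ccc[nH]c-3n2)cc1`) stands furthest off, at 1.9 mg/kg on the same read-out. Compound 4 (`COc1cc([S+](C)[O-])ccc1-c1nc2c[nH]cnc-2n1`) differs from compound 3 in one place (a group of 3 heavy atoms (1 carbon, 1 oxygen, 1 sulfur; no ring) in place of a group of 2 heavy atoms (1 carbon, 1 oxygen; no ring), on an aromatic carbon) on an aromatic carbon, meta to a methoxy group. Among the compounds with values here, no measured pair here shows such a change, so the size of the step remains a matter of expectation. The expected step (no change at the digits printed from compound 3 to compound 4 (within the scatter)) stays within the scatter, with no direction favoured. Compound 4 is estimated at 0.3 mg/kg in this assay with an expected range from 0.08 mg/kg to 1.1 mg/kg for its measurement.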

Compound 4, dose for half-maximal effect: 0.6 mg/kg
Compound 4: middle estimate off by 2.0-fold (0.30 log units), on the low side, and the stated range covers the measured number.
By their numbers in this assay, from the lowest: compounds 2, 3 and 4 (each within the scatter of the next); then compound 1.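

In this assay, the only single-place step among these compounds puts the sulfur-bearing group of 3 heavy atoms in place of methoxy, on the aromatic carbon meta to a methoxy group, and gives a 2.0-fold higher number from compound 3 to compound 4 (0.30 log units; within the scatter). This position therefore takes the exchange with no difference that can be told from repeat scatter. Nothing at hand accounts for the size of the step. From the compounds shown here alone, whether an amine, a carboxylic acid or a longer chain would be taken equally well here stays open. So does whether the remaining methoxy group could be exchanged in the same way.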